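The source may report more compounds than this note shows. Statements on the series, on what has been measured and on what is new or still open speak of the compounds shown alone.

Measured so far:
- compound 1, `COc1ccc(C(=O)COC(=O)c2ccc(N3C(=O)C4CC=CCC4C3=O)cc2)cc1`: 39%
- compound 2, `Cc1ccc(NCC(=O)Nc2ccc(N3C(=O)C4CC=CCC4C3=O)cc2)cc1C`: a limit, < 35%

Both compounds were tested in an assay on isolated protein for inhibition of metabotropic glutamate receptor 5 (Homo sapiens), tested at 10 uM; a higher number here means more inhibition at the concentration tested (going by the name of the read-out), a lower number less inhibition. Within the data shown here, compound 1 gives 39%, which is the only actual number among the two values shown. For compound 2 the assay reports only a limit, < 35%, and not a number. So compound 1 stands as the single measured point, while the other value sits at the limit of < 35% in this assay, at which 1 of the 2 values shown sits. Among the measured compounds shown here, no pair of measured compounds differs in just one place, so no measured step is available to lean on.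

The compound still to be measured is compound 3, `O=C(COC(=O)c1ccc(N2C(=O)C3CC=CCC3C2=O)cc1)c1ccccc1`. It differs from compound 1 in one place: hydrogen in place of methoxy on an aromatic carbon. A methoxy leaves and a hydrogen enters at the para position of the six-membered carbon ring, so the (4-methoxyphenyl)carbonyl becomes a benzoyl. For the measured compounds named here, with no measured step to guide it, the change from compound 1 to compound 3 is expected to stay within the usual scatter of the assay, with a slight lean toward less inhibition. Compound 3 is therefore estimated at 33%, in the range 20% to 48%, an expected step of a number 6 percentage points lower from compound 1 to compound 3 (within the scatter).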

Compound 3, a percentage reported as inhibition, at one concentration (the size of the read-out at that concentration, not a potency): 18%
Beside the measured number, compound 3's estimate is 15 percentage points above it; measured number below the stated range.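

In this assay, replacing methoxy with hydrogen on the aromatic carbon para to a large group gives a number 21 percentage points lower from compound 1 to compound 3 (beyond the scatter). Among these compounds, this is the first measured sign that the group at this place affects the reading: the 4-methoxyphenyl version holds more inhibition than the plain phenyl version, while the rest of the molecule stays the same. Compound 2 is reported only as a limit, so it adds no number in this low range and no second measured step to set beside this one: the limit of < 35% in this assay, at which 1 of the 3 values shown sits.

This single pair cannot show whether the oxygen, the methyl carbon or the two together account for the difference, and both readings come from one concentration, so neither is a potency. From the compounds shown here alone, whether a hydroxyl, a chlorine or a longer ethoxy chain at the same place would match, exceed or fall short of methoxy remains open, as does whether the same exchange would have a similar effect on a different core.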